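The compounds below may be only part of what the source reports. "The series", "measured", "known", "first", "only" and "open" are said of these compounds alone.

Measured in a functional assay on HeLa cells (Homo sapiens) for antiproliferative activity, read by MTT assay, with a stated time of 72 h; on this read-out higher numbers stand for weaker inhibition and lower numbers for stronger inhibition:
- compound 1 `CCCCc1cn(C[C@H](O)[C@H]2OC(=O)C(OCc3ccccc3)=C2OCc2ccccc2)nn1` gives 18100 nM
- compound 2 `O=C1O[C@H]([C@@H](O)Cn2cc(-c3cc(F)cc(F)c3)nn2)C(OCc2ccccc2)=C1OCc1ccccc1` gives 40800 nM
- compound 3 `O=C1O[C@H]([C@@H](O)Cn2cc(CCCCl)nn2)C(OCc2ccccc2)=C1OCc1ccccc1` gives 36700 nM

Compound 1 holds the lowest number of the three; its nearest neighbour is compound 3, with a 2.0-fold higher number from compound 1 to compound 3 (0.31 log units; beyond the scatter), and compound 2 lies a little further off, with a 2.3-fold higher number from compound 1 to compound 2 (0.35 log units; beyond the scatter). Between compound 2 and compound 3 there is a 1.1-fold lower number from compound 2 to compound 3 (0.05 log units; within the scatter), so those two are not separated.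

Compound 4 `O=C1O[C@H]([C@@H](O)Cn2cc(CCO)nn2)C(OCc2ccccc2)=C1OCc1ccccc1` is compound 1 with the change (hydroxy in place of ethyl on a saturated chain carbon, two bonds along the chain from an aromatic carbon), that is, butyl to 2-hydroxyethyl. Within the data shown here, two measured steps bear on it, both leaving compound 1 by a change of the group on the aromatic carbon or along its chain: the chloro for methyl step to compound 3 and the 3,5-difluorophenyl for butyl step to compound 2, each a modest rise in the number beyond the scatter. On that basis a modest upward step in this assay is expected for compound 4, of the order of a 1.9-fold higher number from compound 1 to compound 4 (0.29 log units; within the scatter), though a result within the scatter of compound 1 would not be surprising. Compound 4 is estimated at 35000 nM, with a range from 15000 nM to 80000 nM.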

Compound 4, half-maximal inhibitory concentration: 68800 nM
Compound 4: the middle estimate sits 2.0-fold (0.29 log units) below what was measured; the range from low to high includes it.
By their numbers in this assay, from the lowest: compound 1; then compounds 3, 2 and 4 (each within the scatter of the next).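

In this assay, replacing butyl with 2-hydroxyethyl gives a 3.8-fold higher number from compound 1 to compound 4 (0.58 log units; beyond the scatter), a step beyond the scatter that leaves compound 1 the most potent of the four, since chloro-ended, difluorophenyl and hydroxy-ended replacements at this position all lose ground against butyl. The hydroxy-ended chain is not separated from the other two replacements, with a 1.9-fold higher number from compound 3 to compound 4 (0.27 log units; within the scatter) and a 1.7-fold higher number from compound 2 to compound 4 (0.23 log units; within the scatter), both within the scatter. Among these replacements, the change of end group therefore gives no resolved order, while the unsubstituted butyl chain alone stands apart.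

No measured data explain the loss seen with the hydroxy group. On these data alone, whether an amine, a carboxylic acid or a longer unsubstituted chain such as hexyl would match butyl at this position remains open.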